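Swapping a chlorophenyl for a methoxyanilino group

The compounds below may be only part of what the source reports. "The series", "measured", "known", "first", "only" and "open" are said of these compounds alone.

Among the compounds with values here, compound 3 `Cc1ccc(S(=O)(=O)N(Cc2nnc(Cc3cccc(Cl)c3)o2)c2cccc(Cl)c2C)cc1` gives 158 nM in an assay on CHO cells for displacement of a labelled ligand from prostaglandin E2 receptor EP1 subtype (Homo sapiens) (on this read-out lower numbers stand for stronger inhibition and higher numbers for weaker inhibition), the second highest of the three numbers measured so far: close to compound 2 `Cc1ccc(S(=O)(=O)N(Cc2nnc(Cc3ccc(F)cc3)o2)c2cccc(Cl)c2C)cc1` at 200 nM, with a 1.3-fold lower number from compound 2 to compound 3 (0.10 log units; within the scatter), and far from compound 1 `COc1ccc(Cc2nnc(CN(c3cccc(Cl)c3C)S(=O)(=O)c3ccc(C)cc3)o2)cc1` at 6.31 nM, with a 25-fold higher number from compound 1 to compound 3 (1.40 log units; beyond the scatter). Compound 4 `COc1ccc(NCc2nnc(CN(c3cccc(Cl)c3C)S(=O)(=O)c3ccc(C)cc3)o2)cc1` differs from compound 3 in one place: (4-methoxyphenyl)amino in place of 3-chlorophenyl on a saturated chain carbon bound to an aromatic carbon. Within the data shown here, two measured steps bear on this. Among the measured compounds shown here, exchanging the methoxy-bearing ring of compound 1 gave a 32-fold higher number from compound 1 to compound 2 (1.50 log units; beyond the scatter) and a 25-fold higher number from compound 1 to compound 3 (1.40 log units; beyond the scatter), so a return of the 4-methoxyphenyl points toward a lower number, yet no measured pair shows the added amino link, which leaves the size uncertain. Compound 4 is therefore expected to show a 5.3-fold lower number from compound 3 to compound 4 (0.72 log units; beyond the scatter). The estimate for compound 4 is 30 nM, with a range from 5 nM to 200 nM.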

Compound 4, half-maximal inhibitory concentration: 20 nM
The estimate for compound 4 lay 1.5-fold (0.18 log units) above the measured number; low and high end bracket the measured number.
By their numbers in this assay, from the lowest: compound 1; then compound 4; then compounds 3 and 2 (each within the scatter of the next).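

Putting the amino link back with the 4-methoxyphenyl ring recovers most of the difference seen with the halogen-bearing rings (a 7.9-fold lower number from compound 3 to compound 4 (0.90 log units; beyond the scatter)) and (a 10-fold lower number from compound 2 to compound 4 (1.00 log units; beyond the scatter)). The link itself still has a cost, since adding it to the ring of compound 1 gives (a 3.2-fold higher number from compound 1 to compound 4 (0.50 log units; beyond the scatter)), so in this assay this position accepts the amino link, but compound 1 keeps the lowest number. Nothing measured here explains these shifts. From the compounds shown here alone, it remains open whether an ether oxygen, a methylated amine or a longer chain could replace the amino link, and whether the methoxy group is still needed with that link.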